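The source may hold more compounds than are shown below. What is called first, only, known or untested is meant among the compounds shown, and "the series" means these compounds.

Values in a functional assay on PC-12 cells (Rattus norvegicus) for cytotoxicity, read by MTT assay, with stated times of 3 h and 2 h, tested at 20 uM (on this read-out lower numbers stand for a weaker effect and higher numbers for a stronger effect at the one concentration tested), for the measured compounds:

compound 1 `O=C(CCCCC1CCSS1)NCc1cn(CCCOc2ccc3cc(-c4ccccc4)c(=O)oc3c2)nn1` gives 27.2%
compound 2 `O=C(CCCCC1CCSS1)NCc1cn(CCCOc2ccc3cc(-c4ccc(Cl)cc4)c(=O)oc3c2)nn1` gives 75.6%
compound 3 `O=C(CCCCC1CCSS1)NCc1cn(CCCCOc2ccc3cc(-c4ccc(Cl)cc4)c(=O)oc3c2)nn1` gives 68.4%

The change chloro in place of hydrogen on an aromatic carbon produces the step of a number 48.4 percentage points higher from compound 1 to compound 2 (beyond the scatter). How the core of compound 3 differs from the core of compound 1 is not broken down here; the numbers of compound 3 and compound 2 lie within the scatter of each other.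

Compound 4 `O=C(CCCCC1CCSS1)NCc1cn(CCCCOc2ccc3cc(-c4ccc(Cl)c(Cl)c4)c(=O)oc3c2)nn1` is not yet measured in this assay. It differs from compound 3 by chloro in place of hydrogen on an aromatic carbon, the same kind of change as from compound 1 to compound 2, though the place differs: ortho to a chloro group and meta to a large group, where earlier it was para to a large group. For compound 4 a small step of a number 3.6 percentage points higher from compound 3 to compound 4 (within the scatter) is expected, smaller than the earlier one, because a number 48.4 percentage points higher from compound 1 to compound 2 (beyond the scatter) started from a low number while compound 3 already stands at 68.4%. Compound 4 is estimated at about 72%, with a range from 55% to 88%.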

Compound 4, a percentage reported as activity, at one concentration (the size of the read-out at that concentration, not a potency): 62.9%
The estimate for compound 4 lay 9.1 percentage points above the measured number, and the stated range covers the measured number.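

In this assay, chloro in place of hydrogen on an aromatic carbon gives a number 5.5 percentage points lower from compound 3 to compound 4 (within the scatter), so this step cannot be told apart from the scatter. The change does not carry a fixed size of effect from one core to another in this series: the same change on two cores in this assay, a number 48.4 percentage points higher (beyond the scatter) from compound 1 to compound 2 and a number 5.5 percentage points lower (within the scatter) from compound 3 to compound 4, 53.9 percentage points apart, beyond the scatter of two such steps

This rests on a single pair of steps, and the new chloro also sits at another place, ortho to a chloro group and meta to a large group, so the data do not separate the role of the core from that of the place.

Open, as far as these compounds go, is whether chloro at one and the same place on both cores would give matching steps. Also open, from the compounds shown here alone, is how a methoxy, a nitrile or an amine at that place would read, or a longer chain in the linker.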